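A few compounds are considered here, and "the series" means these few. Any claim that something is new, unique, unknown or untested is made for them only; others in the source may bear on it.

In a physicochemical assay for lipophilicity, using the shake flask method, measured as octanol-water partition, at pH 7.4 (on this read-out higher numbers stand for higher lipophilicity and lower numbers for lower lipophilicity), compound 1 (`CN(C)C(=O)CN1CCC(c2cc3c(-c4ccc(=O)n(C5CCOCC5)c4)ccnc3[nH]2)CC1`) gives 1.1 and compound 2 (`CN(C)C(=O)CN1CCC(c2cc3c(-c4ccc(=O)n(CC5CCOCC5)c4)ccnc3[nH]2)CC1`) gives 1.4 as its number, so the two lie within the scatter of each other. Compound 3 (`CN(C)C(=O)CN1CCC(c2cc3c(-c4ccc(=O)n(C5CCC5)c4)ccnc3[nH]2)CC1`), still unmeasured, differs from compound 2 in one place, with cyclobutyl in place of (oxan-4-yl)methyl on an aromatic nitrogen as the change, on an aromatic nitrogen. Among the measured compounds shown here, only one measured step bears on it: a number 0.30 log units higher from compound 1 to compound 2 (within the scatter) is the change at that same aromatic nitrogen, and it stays within the scatter. For the measured compounds named here, both groups in that step carry the six-membered non-aromatic ring with 1 hetero atom, so it gives no measure for a ring of carbon only, and no measured compound holds one. A modest upward step is therefore expected in this assay on the structural change alone, estimated as a number 0.40 log units higher from compound 2 to compound 3 (beyond the scatter) for now. Compound 3 is expected near 1.8 with an estimated range from 1.4 to 2.2 in that read-out.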

Compound 3, distribution coefficient: 1.9
For compound 3 the middle estimate is 0.10 log units below the measured one; the range from low to high includes it.
By their numbers in this assay, from the lowest: compounds 1 and 2 (each within the scatter of the next); then compound 3.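

In this assay, a change at this aromatic nitrogen now gives a step that clears the scatter: a number 0.50 log units higher from compound 2 to compound 3 (beyond the scatter), with cyclobutyl, a four-membered ring of carbon only, entering in place of (oxan-4-yl)methyl. Against oxan-4-yl the same group gives a number 0.80 log units higher from compound 1 to compound 3 (beyond the scatter), so cyclobutyl stands apart from both groups that carry the six-membered ring with a hetero atom, while those two groups remain within the scatter of each other. Nothing measured here accounts for these steps.

The change alters ring size and removes the hetero atom at once, so the compounds shown do not separate the two. A cyclohexyl group, with a six-membered ring of carbon only, or an oxetan-3-yl group, with a four-membered ring holding oxygen, would bear on that question.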